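Sulfonyl pyridine variation at a high-inhibition plateau

The source may hold more compounds than are shown below. What is called first, only, known or untested is meant among the compounds shown, and "the series" means these compounds.

Compound 3 `CNCc1cn(S(=O)(=O)c2cc(OC)ccn2)c(-c2cccnc2F)c1F` gives 95% in a functional assay on the whole organism (strain Jcl:Sprague-Dawley) for inhibition, with Rattus norvegicus as the target, with stated times of 3 min and 3 h, at a dose of 1 mg/kg by the intravenous route; on this read-out higher numbers stand for more inhibition at the one dose given (going by the name of the read-out) and lower numbers for less inhibition. Compound 3 stands level with compound 1 `CNCc1cn(S(=O)(=O)c2ccccn2)c(-c2cccnc2F)c1F`, which gives 95%, the two together the lowest of three numbers, and its furthest neighbour is compound 2 `CNCc1cn(S(=O)(=O)c2cccc(OC)n2)c(-c2cccnc2F)c1F`, which gives 98%, the gap being a number 3 percentage points lower from compound 2 to compound 3 (within the scatter).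

Compound 4 `CNCc1cn(S(=O)(=O)c2ncccc2C)c(-c2cccnc2F)c1F` differs from compound 3 by 3-methylpyridin-2-yl in place of 4-methoxypyridin-2-yl on a sulfonyl sulfur. Going by the values given here, the steps that bear on this change are a number 3 percentage points higher from compound 1 to compound 2 (within the scatter), no change at the digits printed from compound 1 to compound 3 (within the scatter) and a number 3 percentage points lower from compound 2 to compound 3 (within the scatter); each alters the ring on the sulfonyl sulfur and each stays within the scatter. Compound 4 is therefore expected to show a number 1 percentage points lower from compound 3 to compound 4 (within the scatter) in this assay, no step beyond the scatter. Compound 4 is estimated at 94%, between 82% and 99%.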

Compound 4, a percentage reported as inhibition, in the whole organism at one dose (the size of the read-out at that dose, not a potency): 54%
The estimate for compound 4 lay 40 percentage points above the measured number; the measured number lies below the stated range.
By their numbers in this assay, from the lowest: compound 4; then compounds 1, 3 and 2 (each within the scatter of the next).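

Methyl in place of hydrogen on an aromatic carbon produces the only large fall in this assay (a number 41 percentage points lower from compound 1 to compound 4 (beyond the scatter)), whereas methoxy in place of hydrogen left compound 2 and compound 3 within the scatter of compound 1. The ring exchanges agree (a number 41 percentage points lower from compound 3 to compound 4 (beyond the scatter); a number 44 percentage points lower from compound 2 to compound 4 (beyond the scatter)), so the sulfonyl sulfur carries both methoxypyridines shown without a measurable loss, but not 3-methylpyridin-2-yl. Nothing available accounts for this fall.

As far as these compounds go, it remains open whether the fall is specific to methyl at this ring position, or whether an ethyl group, a chlorine or an amine there would produce it too.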